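This account rests on a few compounds, and the source may have more. Where it says the series, first, only, none or still open, it means among the compounds named here.

Compounds measured so far in a functional assay on CAL1 cells for inhibition of chemerin-like receptor 1 (Homo sapiens), with a stated time of 45 min; a higher number here means a weaker inhibitor, a lower number a stronger inhibitor:

compound 1 `CCCCN(c1nc2c(CO)cccc2o1)[C@H](C)c1ccc(-c2ccccc2-c2nnn[nH]2)cc1` – compound 1 gives 24 nM
compound 2 `Cc1ccc(-c2nc(=O)o[nH]2)c(-c2ccc([C@@H](C)N(CC3CC3)c3nc4c(C(=O)O)cccc4o3)cc2)c1` – compound 2 gives 3.2 nM
compound 3 `CCCCN(c1nc2c(C(=O)NC)cccc2o1)[C@H](C)c1ccc(-c2ccccc2-c2nnn[nH]2)cc1` – compound 3 gives 110 nM

Compound 3 stands highest of the three numbers in this assay; compound 1 is nearest and compound 2 furthest from it. Among the compounds with values here, the one single-change step recorded runs from compound 1 to compound 3, methylcarbamoyl in place of hydroxymethyl on an aromatic carbon, and gives a 4.6-fold higher number from compound 1 to compound 3 (0.66 log units; beyond the scatter). Within the data shown here, compound 2 differs from both in several places and shows only that its own number lies well under that of compound 3.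

Compound 4 `CCCCN(c1nc2c(C(=O)N(C)C)cccc2o1)[C@H](C)c1ccc(-c2ccccc2-c2nnn[nH]2)cc1` is not yet measured. Its change from compound 3 is methyl in place of hydrogen on an amide-type nitrogen, the amide hydrogen of the methylcarbamoyl being replaced. No measured step touches this nitrogen, so nothing shown bears on it directly; the step from compound 1 to compound 3 is the only one in the same part of the molecule, and it was modest. Among the measured compounds shown here, with no comparable step, a small shift in either direction, or none beyond the scatter, is expected in this assay, and the estimate stays close to compound 3. Compound 4 is estimated at 150 nM, range 45 nM to 500 nM. The expected step is a 1.4-fold higher number from compound 3 to compound 4 (0.13 log units; within the scatter).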

Compound 4, half-maximal inhibitory concentration: 13 nM
Beside the measured number, compound 4's estimate is 12-fold (1.06 log units) above it; measured number outside the range, below it.
By their numbers in this assay, from the lowest: compound 2; then compounds 4 and 1 (each within the scatter of the next); then compound 3.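

In this assay, the amide-type nitrogen on this aromatic carbon responds to a single added methyl: methyl in place of the amide hydrogen gives an 8.5-fold lower number from compound 3 to compound 4 (0.93 log units; beyond the scatter) and so runs in the opposite direction to the earlier step, a 4.6-fold higher number from compound 1 to compound 3 (0.66 log units; beyond the scatter) in the same part of the molecule. Dimethylcarbamoyl in place of hydroxymethyl gives a 1.8-fold lower number from compound 1 to compound 4 (0.27 log units; within the scatter) so these two groups are not separated in this assay, and the higher number of compound 3 belongs to the methylcarbamoyl group rather than to every amide shown at this carbon. No measurement shown accounts for the difference between the amide hydrogen and the methyl on this nitrogen.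

Still open, from the compounds shown here alone, is how this nitrogen tolerates other substituents, such as an ethyl group, a pyrrolidine amide or an unsubstituted carboxamide with two hydrogens on the nitrogen. A carboxylic acid at this carbon appears only in compound 2, which differs from the other compounds in several places, so the contribution of that group alone cannot be read from these data.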